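Hydroxyl-bearing side chain on a bicyclic imide core

The source may report more compounds than this note shows. Statements on the series, on what has been measured and on what is new or still open speak of the compounds shown alone.

Compound 1 `CN1C(=O)NC2(CC2(C)C)C1=O`: 30%
Compound 2 `CCCCN1C(=O)NC2(CC2(C)C)C1=O`: 40%

In a functional assay on the whole organism for inhibition, with Mus musculus as the target, at a dose of 40 mg/kg by the oral route (on this read-out higher numbers stand for a stronger effect at the one dose given and lower numbers for a weaker effect), compound 2 gives 40% and stands highest of the two numbers, though compound 1 with 30% lies within the scatter of it. Compound 3 `CCC(CO)N1C(=O)NC2(CC2(C)C)C1=O` differs from compound 2 by 1-(hydroxymethyl)propyl in place of butyl on an amide-type nitrogen in a ring. Among the compounds with values here, the only step measured so far, a number 10 percentage points higher from compound 1 to compound 2 (within the scatter), was within the scatter, and it concerns the same position. Within the data shown here, no measured step therefore points to a change beyond the scatter, and compound 3 is expected to give 40%, between 20% and 60%, which means an expected step of no change at the digits printed from compound 2 to compound 3 (within the scatter).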

Compound 3, a percentage reported as inhibition, in the whole organism at one dose (the size of the read-out at that dose, not a potency): 40%
Estimate against measurement, compound 3: no gap at the digits printed; low and high end bracket the measured number.
By their numbers in this assay, from the lowest: compounds 1, 2 and 3 (each within the scatter of the next).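

Replacing butyl with 1-(hydroxymethyl)propyl on the amide-type nitrogen in a ring gives no change at the digits printed from compound 2 to compound 3 (within the scatter) in this assay and replacing methyl with it gives a number 10 percentage points higher from compound 1 to compound 3 (within the scatter) on the same read-out. This position therefore takes a branched chain carrying a hydroxyl, which adds a hydrogen-bond donor and acceptor, with no shift beyond the scatter. No measurement here offers an explanation for this result.

As far as these compounds go, whether an amine, a carboxylic acid or a chain longer than butyl on this nitrogen would move the number beyond the scatter remains open. Also open, from the compounds shown here alone, is what the hydroxyl contributes apart from the branching.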